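This account rests on a few compounds, and the source may have more. Where it says the series, first, only, none or still open, it means among the compounds named here.

Compound 1, whose structure is `CCCCCCCOC(=O)CCC(=O)N1CCN(CCCOc2cc3c(Nc4ccc(F)c(Cl)c4)ncnc3cc2OC)CC1`, is an ester joined through a short diacid linker to a piperazine that carries the rest of the molecule. Compound 2, `CCCCCCCCOC(=O)CCC(=O)N1CCN(CCCOc2cc3c(Nc4ccc(F)c(Cl)c4)ncnc3cc2OC)CC1`, and compound 3, `CCCCCCCCCCOC(=O)CCC(=O)N1CCN(CCCOc2cc3c(Nc4ccc(F)c(Cl)c4)ncnc3cc2OC)CC1`, share that arrangement and differ from compound 1 only in the length of the ester chain. Compound 4, `CCCCCCCCCCCOC(=O)CCC(=O)N1CCN(CCCOc2cc3c(Nc4ccc(F)c(Cl)c4)ncnc3cc2OC)CC1`, extends the chain once more and has not yet been measured.

In a functional assay on A549 cells (Homo sapiens) for cytotoxicity, read by MTT assay, with a stated time of 24 h, tested at 20 uM (on this read-out higher numbers stand for a weaker effect at the one concentration tested and lower numbers for a stronger effect), compound 1 gives 79.9%. Compound 2 gives 80% in this assay, and compound 3 gives 88.2%. The three numbers lie close together: the step of a number 0.1 percentage points higher from compound 1 to compound 2 (within the scatter) accompanies the change (methyl in place of hydrogen on a saturated chain carbon, seven bonds along the chain from an oxygen next to a carbonyl group), the step of a number 8.3 percentage points higher from compound 1 to compound 3 (within the scatter) accompanies the change (propyl in place of hydrogen on a saturated chain carbon, seven bonds along the chain from an oxygen next to a carbonyl group), and the step of a number 8.2 percentage points higher from compound 2 to compound 3 (within the scatter) is likewise small.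

The move from compound 3 to compound 4 is methyl in place of hydrogen on a saturated chain carbon, ten or more bonds along the chain from an oxygen next to a carbonyl group. Among the compounds with values here, this is the same kind of change as the one from compound 1 to compound 2, though not the same: the two descriptions differ in where along the chain the methyl enters. The two cores differ by propyl in place of hydrogen on a saturated chain carbon, seven bonds along the chain from an oxygen next to a carbonyl group.

Because a number 0.1 percentage points higher from compound 1 to compound 2 (within the scatter) was within the scatter, the step from compound 3 to compound 4 is expected to be about a number 0.2 percentage points lower from compound 3 to compound 4 (within the scatter) in this assay. Compound 4 is therefore estimated at 88%, with a likely range from 78% to 96%.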

Compound 4, a percentage reported as activity, at one concentration (the size of the read-out at that concentration, not a potency): 85.2%
Beside the measured number, compound 4's estimate is 2.8 percentage points above it, and the stated range covers the measured number.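

Adding one more methyl to the long ester chain gives only a small step in this assay, a number 3 percentage points lower from compound 3 to compound 4 (within the scatter), and it reads much the same as the earlier methyl step on the shorter chain: the same change on two cores in this assay, a number 0.1 percentage points higher (within the scatter) from compound 1 to compound 2 and a number 3 percentage points lower (within the scatter) from compound 3 to compound 4, 3.1 percentage points apart, within the scatter of two such steps. Larger extensions of the chain also give small steps, a number 5.2 percentage points higher from compound 2 to compound 4 (within the scatter) and a number 5.3 percentage points higher from compound 1 to compound 4 (within the scatter), and the pair of propyl steps agrees in the same way: the same change on two cores in this assay, a number 8.3 percentage points higher (within the scatter) from compound 1 to compound 3 and a number 5.2 percentage points higher (within the scatter) from compound 2 to compound 4, 3.1 percentage points apart, within the scatter of two such steps. This shows that, among these four compounds, each of these chain extensions carries from one core to another without a detectable difference, but every step lies within the scatter, so it does not show a real effect of a definite size that transfers, nor any trend with chain length.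

The compounds shown leave open whether a much shorter chain, a longer chain still, or an amine or a carboxylic acid in place of the ester chain would give a step beyond the scatter in this assay. They also leave open whether the same agreement between steps would hold at other concentrations or on other cell lines.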